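The source may report more compounds than this note shows. Statements on the series, on what has been measured and on what is new or still open speak of the compounds shown alone.

Working notes on the series. The read-out throughout is a functional assay on NCI-H460 cells (Homo sapiens) for inhibition, read by sulforhodamine B assay, with a stated time of 72 h; on this read-out higher numbers stand for weaker inhibition and lower numbers for stronger inhibition. Compound 1, `Cc1ccc(/C=C/c2nc3cc(Br)ccc3[nH]c2=O)cc1`, gives 0.00812 ug/mL in this assay. Compound 2, `Cc1nc2cc(Br)ccc2nc1Nc1ccc(S(=O)(=O)N2CCCCC2)cc1`, gives 0.00067 ug/mL. Compound 3, `Cc1nc2cc(Br)ccc2nc1Oc1ccc(/N=C\c2ccc(Cl)cc2)cc1`, gives 0.00008 ug/mL, the lowest number of the three; its gap to compound 2 and its wider gap to compound 1 both lie beyond the scatter, so compound 3 stands as the strongest inhibitor among the measured compounds. Going by the values given here, no two measured compounds differ in only one place, so no single step can be read off between them.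

Compound 4, `Cc1nc2cc(Br)ccc2nc1Oc1ccc(/C=N\c2ccc(Cl)cc2)cc1`, is the next compound to be measured. It differs from compound 3 by a group of 9 heavy atoms (7 carbon, 1 nitrogen, 1 chlorine; one six-membered aromatic ring of carbon only) in place of a group of 9 heavy atoms (7 carbon, 1 nitrogen, 1 chlorine; one six-membered aromatic ring of carbon only), on an aromatic carbon. The atoms are the same and only their joining changes, so the closest measured reference is compound 3 itself, at 0.00008 ug/mL. Among the compounds with values here, nothing among the measured compounds shows the effect of this kind of rearrangement, so no measured step can serve as a guide. The expectation is therefore a small step, if any, and none beyond the scatter. The step expected is a 1.9-fold higher number from compound 3 to compound 4 (0.27 log units; within the scatter). Compound 4 is estimated at 0.00015 ug/mL, with a range from 0.00003 ug/mL to 0.0008 ug/mL.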

Compound 4, half-maximal inhibitory concentration: 0.0187 ug/mL
Estimate against measurement, compound 4: 120-fold (2.10 log units) below, and the stated range ends below it.
By their numbers in this assay, from the lowest: compound 3; then compound 2; then compound 1; then compound 4.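

In this assay, turning the carbon-nitrogen double bond round within the group on an aromatic carbon, para to a large group, gives a 230-fold higher number from compound 3 to compound 4 (2.37 log units; beyond the scatter), although the atoms, the six-membered aromatic ring of carbon only and the counted hydrogen-bond donors and acceptors stay the same. Going by these compounds alone, this is the first single-place comparison, and it shows that at this position the number follows how the atoms of the group are joined, so the composition of the group alone does not predict the result for this pair. Nothing available here bears on the reason for a step of this size.

The compounds shown leave open whether a secondary amine or an amide joining the two aromatic rings at this position would stay near compound 3 or near compound 4, or fall elsewhere. They also leave open whether the same reversal gives a step of similar size when the chlorine is replaced by a methoxy group or a carboxylic acid, or when the bromine on the shared core is replaced by hydrogen.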